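A Chloro Step from Compound 1 to Compound 4

This account rests on a few compounds, and the source may have more. Where it says the series, first, only, none or still open, it means among the compounds named here.

In a functional assay on Bel-7402 cells (Homo sapiens) for antiproliferative activity, read by MTT assay, with a stated time of 72 h (a lower number here means a stronger inhibitor, a higher number a weaker inhibitor), compound 1 (`O=C(Nc1ccccc1)C(Cl)Cl`) has no single number, its entry reading "not determined" (no result reported) in the record. Compound 2 (`Cc1cccc(NC(=O)C(Cl)Cl)c1`) stands the same way, with "not determined" (no result reported) as its entry. Only compound 3 (`N#Cc1cccc(NC(=O)C(Cl)Cl)c1`) gives a figure, at 48400 nM in this series. Compound 4 (`O=C(Nc1ccc(Cl)cc1)C(Cl)Cl`) differs from compound 1 by a chloro in place of hydrogen on an aromatic carbon. The data cannot size this step, so compound 3 at 48400 nM serves as the only anchor in this assay. The estimate for compound 4 is 45000 nM as its expected value, with an expected range from 15000 nM to 120000 nM around it.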

Compound 4, half-maximal inhibitory concentration: 49600 nM
Compound 4: the middle estimate sits 1.1-fold (0.04 log units) below what was measured; low and high end bracket the measured number.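

The chloro step from compound 1 to compound 4 cannot be read in this assay, as compound 1 has no single number there. No evidence bears on this result. The compounds shown leave open how the chloro in place of hydrogen changes antiproliferative activity.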